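A few compounds are considered here, and "the series" means these few. Any claim that something is new, unique, unknown or untested is made for them only; others in the source may bear on it.

Compound 1 `COc1c(F)c(F)cc2c(=O)c(C(=O)O)cn(Cc3ccc(-c4ccccc4)cc3)c12` and compound 2 `CNCCNc1cc2c(cc1F)c(=O)c(C(=O)O)cn2Cc1ccc(-c2ccccc2)cc1` share a core and were both tested in an assay on isolated protein for inhibition of DNA topoisomerase 1 (Homo sapiens), with a stated time of 15 min, tested at 200 uM; a lower number here means less inhibition, a higher number more inhibition at the concentration tested (going by the name of the read-out). Compound 1 is reported as "not active" (no number reported). For the measured compounds named here, compound 2 gives 10%, the only number in the set, with compound 1 the one further entry without a number. Compound 3 `CNCCNc1c(F)cc2c(=O)c(C(=O)O)cn(Cc3ccc(-c4ccccc4)cc3)c2c1OC` differs from compound 2 by methoxy in place of hydrogen on an aromatic carbon. Going by the values given here, no step between measured compounds exists, so the change is expected to stay within the scatter: from compound 2 to compound 3 the expected step is a number 2 percentage points lower from compound 2 to compound 3 (within the scatter). Compound 3 is therefore estimated at 8%, between 0% and 25%.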

Compound 3, a percentage reported as inhibition, at one concentration (the size of the read-out at that concentration, not a potency): 10%
For compound 3 the middle estimate is 2 percentage points below the measured one, and the stated range covers the measured number.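

In this assay, methoxy in place of hydrogen on an aromatic carbon, ortho to a (2-(methylamino)ethyl)amino group, gives no change at the digits printed from compound 2 to compound 3 (within the scatter). This first readable step shows that this position can carry methoxy without a measurable effect on the read-out at the concentration tested. No available evidence explains this result. Going by these compounds, whether an ethoxy group, a chlorine or an amine at this position would alter the read-out remains open. So does whether methoxy would have a visible effect on a compound with a larger inhibition reading.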